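Methyl on the fused ring of a quinolinone imine

The source may hold more compounds than are shown below. What is called first, only, known or untested is meant among the compounds shown, and "the series" means these compounds.

Measured compounds and their values:
Compound 1, `Cc1ccc2[nH]c(=O)c(/C=N/c3ccc(C(=O)O)cc3)cc2c1`: "not active" (no number reported)
Compound 2, `O=c1[nH]c2ccccc2cc1/C=N/c1ccccc1O`: 22800 nM
Compound 3, `O=c1[nH]c2ccccc2cc1/C=N/Cc1ccccc1`: "not active" (no number reported)

Of the compounds shown here, three have been measured in a functional assay, read by spectrophotometry, with a stated time of 30 min; a higher number here means a weaker inhibitor, a lower number a stronger inhibitor. Compound 1 was reported as "not active" (no number reported), and compound 3 likewise as "not active" (no number reported), so neither carries a number. Among the measured compounds shown here, compound 2 is therefore the only compound with a numerical read-out, giving 22800 nM in this assay, which places it as the sole reference point for the series.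

Compound 4, `Cc1ccc2[nH]c(=O)c(/C=N/c3ccccc3O)cc2c1`, has not yet been measured. It differs from compound 2 in one place: methyl in place of hydrogen on an aromatic carbon. Compound 1 carries the same methyl on its core, yet with a different aromatic partner on the imine, and was reported inactive, so the effect of the methyl cannot be read from the measured compounds on their own.

Given that the only available number is the one for compound 2, the step to compound 4 is expected to be small, in either direction, and most likely within the scatter. The estimated step of a 1.1-fold higher number from compound 2 to compound 4 (0.04 log units; within the scatter) in this assay reflects that view. Compound 4 is thus expected to give about 25000 nM, with a plausible range from 9000 nM to 70000 nM.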

Compound 4, half-maximal inhibitory concentration: 26200 nM
The estimate for compound 4 lay 1.0-fold (0.02 log units) below the measured number; the range from low to high includes it.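

In this assay, methyl in place of hydrogen on an aromatic carbon of the six-membered aromatic ring of carbon only, part of the fused system of two rings, gives a 1.1-fold higher number from compound 2 to compound 4 (0.06 log units; within the scatter) and so leaves compound 2 and compound 4 indistinguishable in this measurement. Among the compounds shown here, this is the first read-out of the methyl on a compound with a number, as the only earlier compound bearing it, compound 1, was reported without one, and it shows that at this position the methyl leaves the value of the hydroxyl-bearing imine compound in place. No measurement shown here offers an explanation for this result.

From the compounds shown here alone, whether a longer chain, a methoxy group, an amine or a carboxylic acid on this same aromatic carbon would also leave the value in place remains open, as does whether a methyl on the other carbons of that ring would behave like this one. Also open is what the hydroxyl on the imine's aromatic partner contributes, since no compound shown differs from compound 2 in that one place.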